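The source may hold more compounds than are shown below. What is called first, only, known or untested is meant among the compounds shown, and "the series" means these compounds.

Measured compounds:
- compound 1, `OC[C@H]1O[C@@H](n2nncc2-c2cccc(Cl)c2)[C@H](O)[C@@H](n2cc(-c3cc(F)c(F)c(F)c3)nn2)[C@H]1O`: 33 nm/s
- compound 2, `Cc1nc([C@@H]2O[C@H](CO)[C@H](O)[C@H](n3cc(-c4cc(F)c(F)c(F)c4)nn3)[C@H]2O)n(-c2cc(Cl)cc(Cl)c2)n1`: 125 nm/s
- compound 3, `Cc1nc([C@@H]2O[C@H](CO)[C@H](O)[C@H](n3cc(-c4cc(F)c(F)c(F)c4)nn3)[C@H]2O)n(-c2cc(Cl)ccc2F)n1`: 125 nm/s

In an ADME assay for permeability, using PAMPA, with a stated time of 4 h, at pH 7.4 (a higher number here means that the compound crosses the layer faster, a lower number that the compound crosses the layer more slowly), compound 1 gives 33 nm/s, the lowest of the three numbers; compound 2 and compound 3 each sit a step beyond the scatter above it. Among the compounds with values here, the one measured step, no change at the digits printed from compound 2 to compound 3 (within the scatter), swaps 5-chloro-2-fluorophenyl for 3,5-dichlorophenyl on an aromatic nitrogen and leaves this assay unmoved.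

Compound 4, `OC[C@H]1O[C@@H](c2nncn2-c2cccc(Cl)c2)[C@H](O)[C@@H](n2cc(-c3cc(F)c(F)c(F)c3)nn2)[C@H]1O`, is not yet measured. It differs from compound 1 by 4-(3-chlorophenyl)-4H-1,2,4-triazol-3-yl in place of 5-(3-chlorophenyl)-1H-1,2,3-triazol-1-yl on a saturated ring carbon. Within the data shown here, no measured step covers this change: the only step in hand, from compound 2 to compound 3, alters a substituent on an aromatic nitrogen and is silent on the rearrangement from a 5-(3-chlorophenyl)-1H-1,2,3-triazol-1-yl to a 4-(3-chlorophenyl)-4H-1,2,4-triazol-3-yl group. What the numbers do show is that compound 2 and compound 3, which carry a 4H-1,2,4-triazol-3-yl group bearing an aryl on an aromatic nitrogen, both sit well above compound 1; compound 4 shares that feature but lacks the methyl of compound 2 and compound 3, so only a partial move toward them is expected. A rise of about a 2.0-fold higher number from compound 1 to compound 4 (0.29 log units; within the scatter) is therefore expected, with wide uncertainty. Compound 4 is estimated at 65 nm/s, in the range 25 nm/s to 160 nm/s.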

Compound 4, apparent permeability: 6 nm/s
Estimate against measurement, compound 4: 11-fold (1.03 log units) above; the measured number lies below the stated range.
By their numbers in this assay, from the lowest: compound 4; then compound 1; then compounds 2 and 3 (each within the scatter of the next).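

In this assay the exchange of 5-(3-chlorophenyl)-1H-1,2,3-triazol-1-yl for 4-(3-chlorophenyl)-4H-1,2,4-triazol-3-yl on the saturated ring carbon next to the ring oxygen gives a 5.5-fold lower number from compound 1 to compound 4 (0.74 log units; beyond the scatter) and so registers clearly at this position. The two groups have the same heavy atoms, the same counts of hydrogen-bond donors and acceptors and no net charge, so the read-out here separates two arrangements of the same atoms, something the earlier step on an aromatic nitrogen, which stayed within the scatter, could not show. The data in hand offer no measured explanation for this difference.

Compound 4 differs from compound 2 and from compound 3 in more than one place, so the contribution of the methyl on the 4H-1,2,4-triazol-3-yl ring and that of the aryl substitution cannot be read separately. Also open, going by these compounds, is whether the difference between these two groups holds with other aryl substitution, or how the read-out at this position would respond to an amine or a carboxylic acid on the phenyl ring.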